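Methoxycarbonyl in place of thiophen-2-yl on compound 2

A few compounds are considered here, and "the series" means these few. Any claim that something is new, unique, unknown or untested is made for them only; others in the source may bear on it.

Compound 1 `CCCCCCCCc1ccc(OCC(=O)Cn2ncnn2)cc1`: < 5%
Compound 2 `CCCCCCCCc1ccc(OCC(=O)Cn2nnc(-c3cccs3)n2)cc1`: 8%

Among the measured compounds shown here, in an ADME assay on S9 fraction from liver (Rattus norvegicus) for metabolic stability, read by LC-MS, using NADPH, with a stated time of 30 min (on this read-out lower numbers stand for a less stable compound and higher numbers for a more stable compound), compound 2 gives 8%, the only true number so far. Compound 1 gives < 5%, which is a limit of the assay. Compound 3 `CCCCCCCCc1ccc(OCC(=O)Cn2nnc(C(=O)OC)n2)cc1` differs from compound 2 by methoxycarbonyl in place of thiophen-2-yl on an aromatic carbon. For the measured compounds named here, the one measured step that bears on this is a number at least 3 percentage points higher from compound 1 to compound 2 (that floor lies within the scatter), where thiophen-2-yl took the place of hydrogen on an aromatic carbon. Given its small size, no change beyond the scatter is expected, and the expected step is a number 3 percentage points lower from compound 2 to compound 3 (within the scatter). Compound 3 is expected at 5%, with an estimated range of 1% to 14%.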

Compound 3, percent of the compound remaining: < 5%
Compound 3 was reported as a limit (the forecaster's own chance of this, stated with the estimate: 50%); the middle value lies on the limit itself.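

In this assay, methoxycarbonyl in place of thiophen-2-yl on this aromatic carbon gives a number at least 3 percentage points lower from compound 2 to compound 3 (that floor lies within the scatter), so the change cannot be told apart from the scatter. Compound 3 gives a limit of the assay rather than a number, as compound 1 does, so the step between them cannot be read. Read-outs at this position therefore mostly mark a floor: the limit of < 5% in this assay, at which 2 of the 3 values shown sit.

On these data alone, whether an amine or a carboxylic acid on this aromatic carbon would give a number clear of that limit stays open. So does whether any group here can move the result beyond the scatter.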